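The source may hold more compounds than are shown below. What is called first, only, known or untested is meant among the compounds shown, and "the series" means these compounds.

Series notes, tetrazolylacetamide set, read in an assay on HEK293 cells for activation of Kir3.1/Kir3.2 (Homo sapiens), read by thallium flux; on this read-out higher numbers stand for an effect only at larger amounts of compound and lower numbers for an effect already at smaller amounts.

Compound 1 `O=C(Cn1nnc(-c2ccccc2)n1)NC1CC2CCC1C2` carries a phenyl on the shared core; in this assay compound 1 gives 1980 nM. Compound 2 `Cc1cc(NC(=O)Cn2nnc(-c3ccccc3)n2)n(C2CCS(=O)(=O)CC2)n1` is a close relative in which the amide bears a methylpyrazole with a sulfone-containing ring. For compound 2 this assay reports only a limit, > 10000 nM, and no number.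

Compound 3 `Cc1cc(NC(=O)Cn2nnc(-c3ccc(Cl)c(Cl)c3)n2)n(C2CCCCC2)n1` keeps that methylpyrazole but with a cyclohexyl on it and a 3,4-dichlorophenyl on the tetrazole; in this assay compound 3 gives 1220 nM. Among the measured compounds shown here, of the two numbers measured so far compound 3 has the lower one, but compound 1 sits close to it and the gap between the two lies within the scatter, so no order can be claimed between them; compound 2 contributes only a limit.

Compound 4 `COc1ccc(-c2nnn(CC(=O)Nc3cc(C)nn3C3CCCCC3)n2)cc1` is the next member to be measured. It differs from compound 3 in one place: 4-methoxyphenyl in place of 3,4-dichlorophenyl on an aromatic carbon. For the measured compounds named here, no measured pair in this set separates this change, so its effect is unknown here. The step from compound 3 to compound 4 in this assay is expected to be a 2.5-fold higher number from compound 3 to compound 4 (0.39 log units; beyond the scatter), a mild weakening that may not exceed the scatter. For compound 4 the value in this assay is estimated at 3000 nM, within the range 800 nM to 10000 nM.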

Compound 4, half-maximal effective concentration: 175 nM
Estimate against measurement, compound 4: 17-fold (1.23 log units) above; the whole stated range lies above it.
By their numbers in this assay, from the lowest: compound 4; then compounds 3 and 1 (each within the scatter of the next). At a limit, above all of these: compound 2.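

Among the compounds shown here, this position, an aromatic carbon of the five-membered aromatic ring with 4 nitrogen, responds clearly to the choice of aryl group: in this assay, 4-methoxyphenyl in place of 3,4-dichlorophenyl gives a 7.0-fold lower number from compound 3 to compound 4 (0.84 log units; beyond the scatter), and this is the first step in the set that isolates a single change. The earlier compounds shown here could not show this, since compounds 1, 2 and 3 each differ from one another in more than one place. The two groups count the same 8 heavy atoms, with the entering group adding 1 hydrogen-bond acceptor and removing both chlorine atoms, but nothing measured here ties the step to either difference or gives a cause for it.

Still open is whether the step belongs to gaining the methoxy group or to losing the chlorine atoms, as no compound shown pairs a plain phenyl, a 4-chlorophenyl or a 3,4-dimethoxyphenyl with the cyclohexyl-bearing methylpyrazole amide. Also open, from the compounds shown here alone, are a longer ether such as 4-ethoxyphenyl at this place and whether the step carries over to other groups on the amide.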